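The source may hold more compounds than are shown below. What is called first, only, known or untested is meant among the compounds shown, and "the series" means these compounds.

In a functional assay on SW480 cells (Homo sapiens) for antiproliferative activity, read by MTT assay, with a stated time of 48 h (a lower number here means a stronger inhibitor, a higher number a weaker inhibitor), compound 1 `COC/C1=C/C[C@](C)(CCC=C(C)C)/C=C/[C@@H](OC(=O)C=C(C)C)[C@](C)(O)/C=C/C1=O` gives 3850 nM while compound 2 `CC(C)=CCC[C@]1(C)/C=C/[C@@H](OC(=O)C=C(C)C)[C@](C)(O)/C=C/C(=O)/C(CCl)=C\C1` gives 390 nM and compound 3 `CC(C)=CCC[C@]1(C)/C=C/[C@@H](OC(=O)C=C(C)C)[C@](C)(O)/C=C/C(=O)/C(Cn2cc(CO)nn2)=C\C1` gives 2870 nM on the shared core. The measured steps are a 1.3-fold lower number from compound 1 to compound 3 (0.13 log units; within the scatter) and a 7.4-fold higher number from compound 2 to compound 3 (0.87 log units; beyond the scatter), which places compound 3 with compound 1 and well apart from compound 2. Compound 4 `CSC(=S)OC/C1=C/C[C@](C)(CCC=C(C)C)/C=C/[C@@H](OC(=O)C=C(C)C)[C@](C)(O)/C=C/C1=O` differs from compound 3 by a group of 5 heavy atoms (2 carbon, 1 oxygen, 2 sulfur; no ring) in place of a group of 7 heavy atoms (3 carbon, 3 nitrogen, 1 oxygen; one five-membered aromatic ring with 3 hetero atoms), on a saturated chain carbon bound to a double-bonded ring carbon. For the measured compounds named here, no measured compound carries this new group, so the steps at this place give only a rough guide. Compound 2 shows that this place can carry a lower number, with a 9.9-fold lower number from compound 1 to compound 2 (0.99 log units; beyond the scatter) as the largest step seen. A modest drop is therefore expected, estimated as a 2.9-fold lower number from compound 3 to compound 4 (0.46 log units; beyond the scatter). Compound 4 is estimated at 1000 nM, within an expected range from 300 nM to 3300 nM.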

Compound 4, half-maximal inhibitory concentration: 390 nM
For compound 4 the middle estimate is 2.6-fold (0.41 log units) above the measured one; the range from low to high includes it.
By their numbers in this assay, from the lowest: compounds 2 and 4 (each within the scatter of the next); then compounds 3 and 1 (each within the scatter of the next).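

With no change at the digits printed from compound 2 to compound 4 (within the scatter) in this assay, a group without a ring now matches chloro on this saturated chain carbon, so the lower number here is not confined to chloro. The same group gives a 7.4-fold lower number from compound 3 to compound 4 (0.87 log units; beyond the scatter) and a 9.9-fold lower number from compound 1 to compound 4 (0.99 log units; beyond the scatter), which places compound 4 with compound 2 and apart from the compounds carrying the triazolyl and methoxy groups. Nothing measured here accounts for this split. The compounds shown leave open whether an amine or a carboxylic acid at this place would join compounds 2 and 4 or compounds 1 and 3.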